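This account rests on a few compounds, and the source may have more. Where it says the series, first, only, none or still open, it means among the compounds named here.

Three analogues built on the shared core have been measured in an ADME assay on HT-29 cells (Homo sapiens) for cytotoxicity, read by MTT assay, with a stated time of 72 h; on this read-out higher numbers stand for weaker inhibition and lower numbers for stronger inhibition. Compound 1 `C=CC(=O)Nc1cc(Nc2ncc3ncn(-c4ccc(Cl)cc4)c3n2)c(OC)cc1N(C)CCN(C)C` gives 7690 nM, compound 2 `C=CC(=O)Nc1cc(Nc2ncc3ncn(-c4ccc(Br)cc4)c3n2)c(OC)cc1N(C)CCN(C)C` gives 1460 nM, and compound 3 `C=CC(=O)Nc1cc(Nc2ncc3ncn(-c4ccc(Cl)cc4Cl)c3n2)c(OC)cc1N(C)CCN(C)C` gives 20600 nM. Compound 3 thus stands highest of the three numbers: the gap a 2.7-fold higher number from compound 1 to compound 3 (0.43 log units; beyond the scatter) separates it from its nearest neighbour, and the gap a 14-fold higher number from compound 2 to compound 3 (1.15 log units; beyond the scatter) from the furthest. Compound 4 `C=CC(=O)Nc1cc(Nc2ncc3ncn(-c4ccc(F)c(Br)c4)c3n2)c(OC)cc1N(C)CCN(C)C` has not yet been measured; it differs from compound 3 by 3-bromo-4-fluorophenyl in place of 2,4-dichlorophenyl on an aromatic nitrogen. Going by the values given here, two measured steps bear on this change. The step of a 14-fold higher number from compound 2 to compound 3 (1.15 log units; beyond the scatter) shows that replacing a 4-bromophenyl with a 2,4-dichlorophenyl raised the number strongly, and the step of a 2.7-fold higher number from compound 1 to compound 3 (0.43 log units; beyond the scatter) shows a modest rise when a chloro replaced a hydrogen on the ring. Among the compounds with values here, in compound 4 the 2,4-dichlorophenyl leaves and a ring carrying a bromo, as in compound 2, enters, so a move back toward the lower numbers seems likely, although the 3-bromo-4-fluorophenyl itself has no measured counterpart among the three. The step of a 5.2-fold lower number from compound 3 to compound 4 (0.71 log units; beyond the scatter) is therefore expected to lower the number. For compound 4 the estimate in this assay is 4000 nM, within a range from 1000 nM to 15000 nM.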

Compound 4, half-maximal inhibitory concentration: 3640 nM
Estimate against measurement, compound 4: 1.1-fold (0.04 log units) above; low and high end bracket the measured number.
By their numbers in this assay, from the lowest: compound 2; then compound 4; then compound 1; then compound 3.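

In this assay, the exchange of one ring for another with the same count of heavy atoms on the aromatic nitrogen gives a 5.7-fold lower number from compound 3 to compound 4 (0.75 log units; beyond the scatter) and so shows that the high number of compound 3 belongs to the 2,4-dichlorophenyl and not to every ring with two halogens at this place. A bromo on the ring does not by itself restore the low number, as there is a 2.5-fold higher number from compound 2 to compound 4 (0.40 log units; beyond the scatter) for the 3-bromo-4-fluorophenyl in place of 4-bromophenyl, yet a 2.1-fold lower number from compound 1 to compound 4 (0.32 log units; beyond the scatter) puts both bromo compounds, compound 2 and compound 4, below the two compounds with only chloro on the ring, compound 1 and compound 3, and none of the four goes against this order. No measurement among these compounds gives a reason for these differences.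

The compounds shown do not separate the contribution of the fluoro from that of the place of the bromo, since compound 4 differs from compound 2 in both. On these data alone, how a ring carrying a methoxy or a nitrile, or an alkyl chain in place of the phenyl on the aromatic nitrogen, would read in this assay also remains open.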